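Dimethylamino in place of bromo: an aromatase check

A few compounds are considered here, and "the series" means these few. Any claim that something is new, unique, unknown or untested is made for them only; others in the source may bear on it.

Measured compounds:
compound 1 `Brc1ccc(-c2cc3ccccc3[nH]2)cc1` — 4.8%
compound 2 `c1ccc(Cn2c(-c3ccccc3)cc3ccccc32)cc1` — 0%

In an assay on isolated protein for inhibition of Aromatase (Homo sapiens), read by fluorescence, using NADPH, with a stated time of 30 min, tested at 50 uM (on this read-out higher numbers stand for more inhibition at the one concentration tested (going by the name of the read-out) and lower numbers for less inhibition), compound 1 gives 4.8%, and compound 2 gives 0%. Compound 1 holds the higher of the two numbers, but the gap to compound 2 lies within the scatter, so the two numbers cannot be told apart and neither can be called the higher. Both sit close to the floor of the read-out.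

Compound 3 `CN(C)c1ccc(-c2cc3ccccc3[nH]2)cc1` keeps the shared core of compound 1 and differs from it by dimethylamino in place of bromo on an aromatic carbon.

For the measured compounds named here, no step between measured compounds exists, so nothing shows how any change at this position moves the read-out. With compound 1 giving 4.8%, there is little room for a drop and no measured hint of a rise, so the step is expected to be none beyond the scatter. Compound 3 is therefore expected to give 6%, within a range of 0% to 18%, which means an expected step of a number 1.2 percentage points higher from compound 1 to compound 3 (within the scatter).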

Compound 3, a percentage reported as inhibition, at one concentration (the size of the read-out at that concentration, not a potency): 0%
Compound 3: the middle estimate sits 6 percentage points above what was measured, within the range that was stated.
By their numbers in this assay, from the lowest: compounds 2, 3 and 1 (each within the scatter of the next).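

In this assay, for the compounds shown here, dimethylamino in place of bromo on an aromatic carbon gives a number 4.8 percentage points lower from compound 1 to compound 3 (within the scatter), the only step that can be read at this position. The series previously offered no reading of any change here; this one shows that the exchange, which brings in a hydrogen-bond acceptor, cannot be told apart from no change at all. As compound 1 and compound 3 both lie close to the floor of the read-out, the step says little about how far a change at this position could move the number, and no measurement at hand bears on a cause for the result.

Still open, from the compounds shown here alone, is whether any group on this aromatic carbon can lift the number clear of the floor, and a primary amine, a carboxylic acid or a nitrile in place of bromo on the shared core would each test that. A longer chain on the nitrogen, such as diethylamino, would show whether the outcome with dimethylamino holds as the group grows.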